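The source may report more compounds than this note shows. Statements on the series, on what has been measured and on what is new or still open speak of the compounds shown alone.

Measured compounds:
compound 1, `O=c1c(-c2ccc(O)cc2)coc2cc(CC3OC(CO)C(O)C(O)C3O)ccc12`: 0%
compound 2, `O=c1c(-c2ccc(O)cc2)coc2cc(OCCC3OCCCO3)ccc12`: 57.6%

In a functional assay on mitochondria (Cricetulus griseus) for inhibition of Monoamine oxidase (Homo sapiens), tested at 0.9 uM (on this read-out lower numbers stand for a weaker effect and higher numbers for a stronger effect at the one concentration tested), compound 1 gives 0%, while compound 2 gives 57.6%. Compound 2 thus stands highest of the two numbers; its nearest neighbour is compound 1, whose number lies lower by a gap that is beyond the scatter. Going by the values given here, no pair of these two differs in only one place, so no single step can be read from the measured set.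

Compound 3, `O=C(O)CCCCCCOc1ccc2c(=O)c(-c3ccc(O)cc3)coc2c1`, is not yet measured in this assay. Relative to compound 2 the change is a group of 7 heavy atoms (5 carbon, 2 oxygen; no ring) in place of a group of 6 heavy atoms (4 carbon, 2 oxygen; one six-membered non-aromatic ring with 2 hetero atoms), on a saturated chain carbon, two bonds along the chain from an oxygen on an aromatic ring.

Among the compounds with values here, there is no measured step to lean on, and the only other compound, compound 1, carries a different kind of group at the corresponding position. The expectation is a step of moderate size downward from compound 2 to compound 3, a number 27.6 percentage points lower from compound 2 to compound 3 (beyond the scatter), in this assay, because compound 2 gives 57.6% and compound 1, with its more polar group, gives 0%. For compound 3 the estimate is 30%, with the likely range from 5% to 60%.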

Compound 3, a percentage reported as inhibition, at one concentration (the size of the read-out at that concentration, not a potency): 71.2%
Estimate against measurement, compound 3: 41.2 percentage points below; measured number above the stated range.
By their numbers in this assay, from the lowest: compound 1; then compound 2; then compound 3.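

In this assay, replacing the group with the six-membered non-aromatic ring by 4-carboxybutyl gives a number 13.6 percentage points higher from compound 2 to compound 3 (beyond the scatter). This position, on a saturated chain carbon, two bonds along the chain from an oxygen on an aromatic ring, therefore does not need that ring to keep the read-out, and an open chain ending in a carboxylic acid is accepted. No measurement available here accounts for the rise.

Because the ring leaves and the carboxylic acid enters in the same step, the two changes cannot be separated. An ester or amine at the chain end, or a longer chain, would test which feature carries the read-out, and a full concentration series would be needed to speak of anything beyond a stronger or weaker effect at the one concentration tested.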